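The source may report more compounds than this note shows. Statements on the series, on what has been measured and on what is new or still open speak of the compounds shown alone.

Compound 2 `Cc1ccccc1-n1cc(-c2cccc(NS(=O)(=O)c3c[nH]c(=O)[nH]c3=O)c2)nn1` and compound 1 `Cc1cccc(-n2cc(-c3ccccc3NS(=O)(=O)c3c[nH]c(=O)[nH]c3=O)nn2)c1` share a common core and were both tested in a functional assay on SGC-7901 cells (Homo sapiens) for antiproliferative activity, read by MTT assay, with a stated time of 24 h; a lower number here means a stronger inhibitor, a higher number a weaker inhibitor. In that assay compound 1 gives 3510 nM, while compound 2 gives 9230 nM. Compound 2 thus stands with the higher of the two numbers, and the gap to compound 1 lies beyond the usual scatter. The two compounds differ in more than one place, so the comparison shows only what the two values show, not a single counted change.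

Compound 3 `O=c1[nH]cc(S(=O)(=O)Nc2cccc(-c3cn(-c4cccc(F)c4)nn3)c2)c(=O)[nH]1` is the next compound and has not yet been measured. It differs from compound 2 in one place: 3-fluorophenyl in place of 2-methylphenyl on an aromatic nitrogen, with the 3-fluorophenyl sitting on an aromatic nitrogen of the five-membered aromatic ring with three nitrogens.

No measured step of this exact kind exists among the compounds shown. The step from compound 2 to compound 3 is expected to be a 1.5-fold lower number from compound 2 to compound 3 (0.19 log units; within the scatter), a modest move toward a lower number that may not clear the scatter. Compound 3 is estimated to give 6000 nM in this assay, within a range from 2500 nM to 15000 nM.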

Compound 3, half-maximal inhibitory concentration: > 20000 nM
Compound 3: a limit, no number; the forecaster's own chance of this, stated with the estimate: 5%; at least 3.3-fold (0.52 log units) between middle value and limit.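

Within the data shown here, putting 3-fluorophenyl in place of 2-methylphenyl on an aromatic nitrogen gives an at least 2.1-fold higher number from compound 2 to compound 3 (0.33 log units; beyond the scatter), the first reading of a single change at this position, and it shows that the position is not indifferent to which phenyl group it carries, even though the two groups are alike in heavy-atom count, carry no hydrogen-bond donors or acceptors and have no net charge. In this assay compound 3 gives > 20000 nM, which is a limit of the assay and not a number, so the step fixes a direction and a minimum size, while its full size stays unknown, and this reading is the only one of its kind among the compounds shown: the limit of > 20000 nM in this assay, at which 1 of the 3 values shown sits.

The compounds shown leave open whether the change in the reading goes with the loss of the methyl group or with the arrival of the fluorine, as the single step swaps both together. They also leave open how an unsubstituted phenyl, or a saturated ring such as cyclohexyl, would read on this same nitrogen.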